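This account rests on a few compounds, and the source may have more. Where it says the series, first, only, none or still open, it means among the compounds named here.

Three close relatives of one structure were examined in a functional assay on A-375 cells (Homo sapiens) for antiproliferative activity, read by trypan blue exclusion, with a stated time of 48 h, tested at 1 uM; a lower number here means a stronger effect, a higher number a weaker effect of the compound at the concentration tested. Compound 1 `CC(=O)Nc1nc(-c2cccc(NS(=O)(=O)c3ccc(C#CCO)cc3)c2)cs1` carries a hydroxymethyl on a triple-bonded carbon, and in this assay compound 1 gives 81.3%. Compound 2 `CC(=O)Nc1nc(-c2cccc(NS(=O)(=O)c3ccc(C#C[Si](C)(C)C)cc3)c2)cs1` differs from it in a single place: a group of 4 heavy atoms (3 carbon, 1 silicon; no ring) in place of a group of 2 heavy atoms (1 carbon, 1 oxygen; no ring), on a triple-bonded carbon. In this assay compound 2 gives 94.3%, so that a number 13 percentage points higher from compound 1 to compound 2 (beyond the scatter). Compound 3 `CC(=O)Nc1nc(-c2cccc(NS(=O)(=O)c3cccc(C#CCO)c3)c2)cs1` is built from the same atoms as compound 1, joined differently; the difference between the two cores is not broken down here. In this assay compound 3 gives 85.4%, a number that sits within the usual scatter of both compound 1 and compound 2.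

Compound 4 `CC(=O)Nc1nc(-c2cccc(NS(=O)(=O)c3cccc(C#C[Si](C)(C)C)c3)c2)cs1` has not yet been measured. It stands to compound 3 exactly as compound 2 stands to compound 1: a group of 4 heavy atoms (3 carbon, 1 silicon; no ring) in place of a group of 2 heavy atoms (1 carbon, 1 oxygen; no ring), on a triple-bonded carbon. The place is described in the same words for both pairs, so this is the same change carried out on a different core. Among these compounds the change occurs only twice, so any expectation rests on one measured step. Compound 4 is expected to show a number 9.6 percentage points higher from compound 3 to compound 4 (within the scatter) in this assay, because the same change earlier gave a number 13 percentage points higher from compound 1 to compound 2 (beyond the scatter). The starting point matters: compound 3 already stands at 85.4%, and a read-out of this kind has little room left above it. Weighing those two points, compound 4 is estimated at 95% in this assay, with an expected range from 85% to 102%.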

Compound 4, a percentage reported as activity, at one concentration (the size of the read-out at that concentration, not a potency): 61.6%
Beside the measured number, compound 4's estimate is 33.4 percentage points above it; the measured number lies below the stated range.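

In this assay, putting the group of 4 heavy atoms (3 carbon, 1 silicon) in place of the hydroxymethyl on the triple-bonded carbon gives a number 23.8 percentage points lower from compound 3 to compound 4 (beyond the scatter), so on this core the same change strengthens the effect at the concentration tested rather than weakening it. Set beside the earlier step, the change does not carry over from one core to the other, not even in its direction: the same change on two cores in this assay, a number 13 percentage points higher (beyond the scatter) from compound 1 to compound 2 and a number 23.8 percentage points lower (beyond the scatter) from compound 3 to compound 4, 36.8 percentage points apart, beyond the scatter of two such steps This shows that, within these two pairs, the result of the change cannot be read across from one core to the other, but it does not show why the two cores part ways, and two pairs give no rule for any further core.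

On these data alone, only the hydroxymethyl and this silicon-bearing group appear on the triple-bonded carbon, so it remains open whether a tert-butyl group, an aminomethyl group or a longer alcohol chain would also follow opposite courses on the two cores. As far as these compounds go, each number is also a read-out at a single concentration, not a potency, so how the compounds would compare across a range of concentrations remains open too.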